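A Second Fluorine on the Carbamate Aryl Ring

The source may hold more compounds than are shown below. What is called first, only, known or untested is meant among the compounds shown, and "the series" means these compounds.

Compound 1 `CC(C)=CCC/C(C)=C/CC1Cc2c(OCCCNC(=O)c3cccs3)cc(=O)n(CCCO)c2CC1(C)C` gives 72.8% in a functional assay on PANC-1 cells (Homo sapiens) for inhibition, read by MTT assay, with a stated time of 24 h, tested at 10 uM (a higher number here means more inhibition at the concentration tested (going by the name of the read-out), a lower number less inhibition), while compound 2 `CC(C)=CCC/C(C)=C/CC1Cc2c(OC(=O)Nc3ccc(F)cc3)cc(=O)n(CCCO)c2CC1(C)C` gives 43.9%, the step being a number 28.9 percentage points lower from compound 1 to compound 2 (beyond the scatter). Compound 2 thus stands lowest of the two numbers shown. Compound 3 `CC(C)=CCC/C(C)=C/CC1Cc2c(OC(=O)Nc3ccc(F)c(F)c3)cc(=O)n(CCCO)c2CC1(C)C` differs from compound 2 only by fluoro in place of hydrogen on an aromatic carbon. For the measured compounds named here, the one measured step swaps the whole group on the ring oxygen and so offers no guide to a single added fluorine; no step beyond the scatter is therefore expected, so the expected change is a number 1.1 percentage points higher from compound 2 to compound 3 (within the scatter). Compound 3 is estimated at 45%, within 28% to 62%.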

Compound 3, a percentage reported as inhibition, at one concentration (the size of the read-out at that concentration, not a potency): 43.7%
Compound 3: middle estimate off by 1.3 percentage points, on the high side, and the stated range covers the measured number.
By their numbers in this assay, from the lowest: compounds 3 and 2 (each within the scatter of the next); then compound 1.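

In this assay the added fluoro, ortho to a fluoro group and meta to a large group, gives a number 0.2 percentage points lower from compound 2 to compound 3 (within the scatter) and so does not separate the 3,4-difluorophenyl compound from the 4-fluorophenyl one. Set against the group on the ring oxygen of compound 1, the (3,4-difluorophenyl)carbamoyl group gives a number 29.1 percentage points lower from compound 1 to compound 3 (beyond the scatter) even with the second fluoro in place. Nothing at hand explains why the added fluoro makes no difference beyond the scatter. Going by these compounds, whether chloro, methoxy or an amine on the same aromatic carbon would shift the number remains open.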